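Swapping one aromatic ring for another on the shared core

The source may hold more compounds than are shown below. What is called first, only, known or untested is meant among the compounds shown, and "the series" means these compounds.

Compound 3 `c1cncc(-c2cccc3c2CCC3c2ncc[nH]2)c1` gives 36% in a functional assay on CHO cells for agonist activity at Alpha-1A adrenergic receptor (Homo sapiens), read by FLIPR and calcium flux (a lower number here means a smaller maximal response, a higher number a larger maximal response), the lowest of the three measured values. Compound 1 `c1ccc2c(c1)CCC2c1ncc[nH]1`, with hydrogen at that position, gives 54%, and compound 2 `CS(=O)(=O)Nc1cccc2c1CCC2c1ncc[nH]1` gives 87%. Compound 4 `Cn1cc(-c2cccc3c2CCC3c2ncc[nH]2)cn1` carries 1-methyl-1H-pyrazol-4-yl in place of pyridin-3-yl on an aromatic carbon. Within the data shown here, two steps bear on this change: a number 18 percentage points lower from compound 1 to compound 3 (beyond the scatter) and a number 51 percentage points lower from compound 2 to compound 3 (beyond the scatter). Among the measured compounds shown here, both run downward when pyridin-3-yl enters, but no measured step compares two aromatic rings at this position with each other. Because compound 3 already gave 36% with one aromatic ring there, the step of a number 4 percentage points higher from compound 3 to compound 4 (within the scatter) is expected to stay within the scatter. Compound 4 is therefore expected to give 40%, between 25% and 60%.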

Compound 4, largest response reached (Emax), in percent of the reference or control that the assay uses: 12%
Estimate against measurement, compound 4: 28 percentage points above; the whole stated range lies above it.
By their numbers in this assay, from the lowest: compound 4; then compound 3; then compound 1; then compound 2.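

In this assay, two aromatic rings of equal heavy-atom count are not interchangeable at this position: 1-methyl-1H-pyrazol-4-yl in place of pyridin-3-yl gives a clear drop (a number 24 percentage points lower from compound 3 to compound 4 (beyond the scatter)). The pyrazole also falls well short of both hydrogen (a number 42 percentage points lower from compound 1 to compound 4 (beyond the scatter)) and methanesulfonamido (a number 75 percentage points lower from compound 2 to compound 4 (beyond the scatter)), so the identity of the ring matters, not merely the presence of one. Nothing available explains the gap between the two rings. Still open, from the compounds shown here alone, is how a simple amine or a carboxylic acid would behave on this aromatic carbon, and whether a phenyl ring without hetero atoms would follow either ring.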